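The compounds below may be only part of what the source reports. "The series", "measured", "known", "first", "only" and "open" are said of these compounds alone.

In a toxicity assay on MDCK cells (Canis lupus familiaris) for cytotoxicity, read by CCK-8 assay, with a stated time of 48 h (on this read-out higher numbers stand for lower toxicity in this test and lower numbers for higher toxicity in this test), compound 1 (`CCOc1ccc(C(=O)NNc2c(Br)cccc2Br)cc1`) gives > 100000 nM, which is a limit of the assay and not a number. Among the compounds with values here, compound 2 (`CCc1ccc(C(=O)NNc2c(Br)cccc2Br)cc1`) gives > 100000 nM, again a limit, so its position cannot be given as a number, and the only other value shown is also a limit. Compound 3 (`O=C(NNc1c(Br)cccc1Br)c1ccc(OCC(F)(F)F)cc1`) carries 2,2,2-trifluoroethoxy in place of ethyl on an aromatic carbon, para to a large group: 2,2,2-trifluoroethoxy in place of ethyl on an aromatic carbon. Within the data shown here, the one measured step that bears on this change is a step that the two limits leave unreadable from compound 1 to compound 2, which exchanges ethoxy for ethyl, and its size cannot be read. Among the measured compounds shown here, all the evidence on the series so far is the limit of > 100000 nM in this assay, at which 2 of the 2 values shown sit. On that basis, no step beyond the scatter is expected in this assay, and nothing shown points to a direction. The estimated step is a number no higher from compound 2 to compound 3 (the limit leaves the size open). Compound 3 is expected to give about 100000 nM, with an estimated range from 40000 nM to 200000 nM, and the assay will most likely report only a limit again.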

Compound 3, half-maximal cytotoxic concentration: > 100000 nM
Compound 3: no number, only a limit (the forecaster's own chance of this, stated with the estimate: 85%); the middle value lies on the limit itself.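

In this assay compound 3 gives > 100000 nM, which is a limit of the assay and not a number. Within the data shown here, no step among compound 1, compound 2 and compound 3 can be read. The compounds shown leave open whether ethoxy, ethyl and 2,2,2-trifluoroethoxy differ at all in this assay.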